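Working notes on compound 4 beside compounds 1 to 3

The source may report more compounds than this note shows. Statements on the series, on what has been measured and on what is new or still open speak of the compounds shown alone.

Compound 1 `COC(=O)c1ccc(NCc2cncn2Cc2ccccc2Cl)cc1-c1ccccc1` gives 10000 nM in a toxicity assay on NIH3T3 cells (Mus musculus) for cytotoxicity, read by resazurin assay; a lower number here means that less compound is needed, a higher number that more compound is needed for the effect. Compound 2 `COC(=O)c1ccc(NCc2cncn2Cc2ccc(-c3ccccc3)cc2)cc1-c1ccccc1` in this assay reaches only a limit, > 1000 nM, and not a number. For compound 3 `COC(=O)c1ccc(NCc2cncn2Cc2ccccc2C(C)(C)C)cc1-c1ccccc1` the entry in this assay reads "not determined" (no result reported). The step that the limit leaves unreadable from compound 1 to compound 2 is therefore unreadable in size, as the limit of > 1000 nM in this assay, at which 1 of the 3 values shown sits, shows. Compound 2 thus stands at that limit, without a single number of its own. Compound 4 `c1ccc(-c2ccc(Cn3cncc3CNc3ccc(-c4onc5ccccc45)c(-c4ccccc4)c3)cc2)cc1` differs from compound 2 by a group of 9 heavy atoms (7 carbon, 1 nitrogen, 1 oxygen; one five-membered aromatic ring with 2 hetero atoms, one six-membered aromatic ring of carbon only) in place of a group of 4 heavy atoms (2 carbon, 2 oxygen; no ring), on an aromatic carbon. Among the measured compounds shown here, no measured step covers this exchange, and the single step on record gives no size to carry over. Expected for compound 4 in this assay is 10000 nM, range 2000 nM to 50000 nM. The expected step that the limit leaves unreadable from compound 2 to compound 4 stays within the scatter.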

Compound 4, half-maximal effective concentration: > 10000 nM
Compound 4: no number, only a limit (the forecaster's own chance of this, stated with the estimate: 60%); the middle value sits exactly at the limit.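

Among the compounds shown here, compound 2 and compound 4 each give only a limit in this assay, so no step between them can be read. The compounds shown leave open what size of effect, if any, follows when the group of compound 4 replaces methoxycarbonyl.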